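The compounds below may be only part of what the source reports. "The series", "measured", "known", "first", "only" and "open" are said of these compounds alone.

Compound 1, `O=S(=O)(/C=C/c1ccccn1)c1cccc(F)c1`, gives 1680 nM in an assay on U2OS cells for activation of nuclear factor erythroid 2-related factor 2 (Homo sapiens), read by beta-arrestin recruitment, with a stated time of 6 h; a lower number here means that less compound is needed, a higher number that more compound is needed for the effect.
Compound 2, `O=S(=O)(/C=C/c1ncccc1F)c1cccc(F)c1`, gives 474 nM in this assay.
Compound 3, `O=S(=O)(/C=C/c1ccccn1)c1ccc(F)cc1`, gives 3100 nM in this assay.

Compound 1 and compound 2 share a core and differ in one place: fluoro in place of hydrogen on an aromatic carbon. That single change brought a 3.5-fold lower number from compound 1 to compound 2 (0.55 log units; beyond the scatter), a modest but real gain in this assay.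

Compound 3 has the same atoms as compound 1, joined differently; the difference between the two cores is not broken down here. Their two values in this assay lie within the usual scatter of each other, so nothing can be said about which of the two needs less compound. Compound 2, by contrast, clearly needs less compound than compound 3.

Compound 4, `O=S(=O)(/C=C/c1ncccc1F)c1ccc(F)cc1`, has not yet been measured. It stands to compound 3 as compound 2 stands to compound 1: the difference is fluoro in place of hydrogen on an aromatic carbon, and the surroundings of the place match word for word, so this is the same change made on the core of compound 3.

Among the measured compounds shown here, with only one measured example of the change, the expectation for compound 4 is that the step in this assay will be of about the same size as before. This rests on the measured step of a 3.5-fold lower number from compound 1 to compound 2 (0.55 log units; beyond the scatter). For compound 4 the expected step is a 3.4-fold lower number from compound 3 to compound 4 (0.54 log units; beyond the scatter). Compound 4 is therefore estimated to give about 900 nM in this assay, most likely between 400 nM and 2000 nM.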

Compound 4, half-maximal effective concentration: 542 nM
Compound 4: middle estimate off by 1.7-fold (0.22 log units), on the high side, within the range that was stated.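

Placing the same fluoro on an aromatic carbon of the core of compound 3 gave a 5.7-fold lower number from compound 3 to compound 4 (0.76 log units; beyond the scatter) in this assay, so the gain seen on the core of compound 1 appears again on a second core. Set side by side, the two steps are no further apart than repeated measurements would allow: the same change on two cores in this assay, a 3.5-fold lower number (0.55 log units; beyond the scatter) from compound 1 to compound 2 and a 5.7-fold lower number (0.76 log units; beyond the scatter) from compound 3 to compound 4, 1.6-fold (0.21 log units) apart, within the scatter of two such steps. This shows that the change carried over between these two closely related cores at a similar size, but two examples cannot establish a general rule, and they do not show why the number falls or whether the step would hold on a more different core.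

The compounds shown have only hydrogen or fluoro at this place, so it remains open whether chloro, methyl, methoxy or a nitrile there would lower the number as well, stay level with hydrogen, or raise it. On these data alone, it also remains open whether the fluoro step would survive on a core that carries an amine or a carboxylic acid elsewhere, where the surroundings of the change would no longer match those of these two pairs.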